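Bromo for Chloro on the Shared Core: A Forecast

A few compounds are considered here, and "the series" means these few. Any claim that something is new, unique, unknown or untested is made for them only; others in the source may bear on it.

Compound 1 `Fc1ccc(-c2nn(-c3ccccc3)cc2-c2nc3cc(Cl)ccc3[nH]2)cc1` — 1320 nM
Compound 2 `Fc1ccc(-c2nn(-c3ccccc3)cc2-c2nc3cc(Br)ccc3[nH]2)cc1` — 5830 nM
Compound 3 `Clc1ccc(-c2nn(-c3ccccc3)cc2-c2nc3cc(Cl)ccc3[nH]2)cc1` — 1340 nM

These three compounds were tested in a functional assay on A549 cells (Homo sapiens) for antiproliferative activity, read by MTT assay, with a stated time of 48 h; a lower number here means a stronger inhibitor, a higher number a weaker inhibitor. In this assay compound 1 gives 1320 nM and compound 3 gives 1340 nM; the two cores differ only by chloro in place of fluoro on an aromatic carbon, and the step is a 1.0-fold higher number from compound 1 to compound 3 (0.01 log units; within the scatter). Compound 2 gives 5830 nM; it differs from compound 1 by bromo in place of chloro on an aromatic carbon, and that change made a 4.4-fold higher number from compound 1 to compound 2 (0.65 log units; beyond the scatter).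

Compound 4 `Clc1ccc(-c2nn(-c3ccccc3)cc2-c2nc3cc(Br)ccc3[nH]2)cc1` is not yet measured. It differs from compound 3 by bromo in place of chloro on an aromatic carbon, the same change at the same place as between compound 1 and compound 2. The expected step is a 4.4-fold higher number from compound 3 to compound 4 (0.64 log units; beyond the scatter), close to the earlier one, because a 1.0-fold higher number from compound 1 to compound 3 (0.01 log units; within the scatter) shows that compound 1 and compound 3 sit together. Compound 4 is therefore estimated at 5900 nM, expected between 2500 nM and 13000 nM.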

Compound 4, half-maximal inhibitory concentration: 2170 nM
Compound 4: the middle estimate sits 2.7-fold (0.43 log units) above what was measured; measured number outside the range, below it.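

In this assay, bromo in place of chloro now gives a 1.6-fold higher number from compound 3 to compound 4 (0.21 log units; within the scatter), so on this core the change does not carry over at the size seen on the core of compound 1: the same change on two cores in this assay, a 4.4-fold higher number (0.65 log units; beyond the scatter) from compound 1 to compound 2 and a 1.6-fold higher number (0.21 log units; within the scatter) from compound 3 to compound 4, 2.7-fold (0.44 log units) apart, beyond the scatter of two such steps

The other change, chloro in place of fluoro, shifts too: with bromo on the core it gives a 2.7-fold lower number from compound 2 to compound 4 (0.43 log units; beyond the scatter), unlike the step with chloro on the core: the same change on two cores in this assay, a 1.0-fold higher number (0.01 log units; within the scatter) from compound 1 to compound 3 and a 2.7-fold lower number (0.43 log units; beyond the scatter) from compound 2 to compound 4, 2.7-fold (0.44 log units) apart, beyond the scatter of two such steps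

Together, these four compounds show that the effect of each halogen swap depends on the other halogen, but they do not show why, or whether this holds on any other core.

The compounds shown leave open how a methyl group, a methoxy group or an amine would behave in the place of the bromo or chloro. They also leave open whether the effect of such a group would depend on the other halogen in the same way.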